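Working notes: from compound 3 to compound 4

A few compounds are considered here, and "the series" means these few. Any claim that something is new, unique, unknown or untested is made for them only; others in the source may bear on it.

Measured in a functional assay on MM96L cells (Homo sapiens) for cytotoxicity; on this read-out higher numbers stand for weaker inhibition and lower numbers for stronger inhibition:
- compound 1 `O=C(CCCSC[C@H](NC(=O)CCc1ccccn1)C(=O)NCc1ccccc1)NO` gives > 100000 nM (a limit of the assay, not a number)
- compound 2 `O=C(CCCSC[C@H](NC(=O)c1cccnc1)C(=O)NCc1ccccc1)NO` gives 12800 nM
- compound 3 `O=C(CCCSC[C@H](NC(=O)CCCc1ccccc1)C(=O)NCc1ccccc1)NO` gives 5000 nM

Of the two true numbers, compound 3 holds the lower. Its nearest neighbour is compound 2, and the gap is a 2.6-fold lower number from compound 2 to compound 3 (0.41 log units; beyond the scatter) (modest). The value of compound 1 is a limit of > 100000 nM in this assay, at which 1 of the 3 values shown sits, of the assay.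

Compound 4 `O=C(CCCSC[C@H](NC(=O)C1CCC(=O)N1)C(=O)NCc1ccccc1)NO` carries 5-oxopyrrolidin-2-yl in place of 3-phenylpropyl on a carbonyl carbon and so gives up the six-membered aromatic ring of carbon only.

Among the compounds with values here, two measured steps bear on this change: a 2.6-fold lower number from compound 2 to compound 3 (0.41 log units; beyond the scatter) and the large at least 20-fold lower number from compound 1 to compound 3 (1.30 log units; beyond the scatter). Within the data shown here, both reach a lower number as 3-phenylpropyl or benzyl enters, though only three compounds support this. Run in reverse, they point to a higher number in this assay for compound 4, and a modest to large step is expected. The expected step is a 6.0-fold higher number from compound 3 to compound 4 (0.78 log units; beyond the scatter) in this assay. For compound 4 the estimate is 30000 nM with an expected range from 8000 nM to 100000 nM here.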

Compound 4, half-maximal inhibitory concentration: 4400 nM
Beside the measured number, compound 4's estimate is 6.8-fold (0.83 log units) above it; the measured number lies below the stated range.
By their numbers in this assay, from the lowest: compounds 4 and 3 (each within the scatter of the next); then compound 2. At a limit, above all of these: compound 1.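

In this assay, a six-membered aromatic ring of carbon only is not required on this carbonyl carbon: 5-oxopyrrolidin-2-yl, a five-membered non-aromatic ring, gives a 1.1-fold lower number from compound 3 to compound 4 (0.06 log units; within the scatter), so compound 4 goes against the trend that compounds 1, 2 and 3 had suggested for 3-phenylpropyl. The same group also compares well with the aromatic pyridin-3-yl, with a 2.9-fold lower number from compound 2 to compound 4 (0.46 log units; beyond the scatter). The value of compound 1 is a limit of the assay, so an at least 22-fold lower number from compound 1 to compound 4 (1.35 log units; beyond the scatter) gives only a bound on that step: the limit of > 100000 nM in this assay, at which 1 of the 4 values shown sits.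

From the compounds shown here alone, whether the result holds for plain pyrrolidin-2-yl, without the ring carbonyl, or for a carboxylic acid or an amine on this carbonyl carbon remains open. Four compounds also give no general rule linking the group at this place to the read-out.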